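This account rests on a few compounds, and the source may have more. Where it says the series, first, only, none or still open, it means among the compounds named here.

Among the compounds with values here, the three measured members share one core. Compound 1 `Cc1cc(C)nc(SCc2cc(=O)c3cc(Cl)ccc3o2)n1` carries a chloro on an aromatic carbon; in a functional assay on HEp-2 cells (Homo sapiens) for cytotoxicity, read by MTT assay, with a stated time of 72 h (a lower number here means a stronger inhibitor, a higher number a weaker inhibitor), compound 1 gives > 25000 nM, which is a limit of the assay and not a number. Compound 2 `Cc1cc(C)nc(SCc2cc(=O)c3ccccc3o2)n1` lacks that chloro; in this assay compound 2 gives > 25000 nM, again a limit rather than a number. Compound 3 `Cc1nnc(SCc2cc(=O)c3cc(Cl)ccc3o2)o1` is the third measured member; in this assay compound 3 gives > 25000 nM, also a limit. Within the data shown here, the only step between compounds differing in a single place, a step that the two limits leave unreadable from compound 1 to compound 2, is hydrogen in place of chloro on an aromatic carbon, and the two limits leave its size unreadable. Compound 2 therefore stands only at a limit, and the set as a whole is summed up by the limit of > 25000 nM in this assay, at which 3 of the 3 values shown sit.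

Compound 4 `Cc1ccc2oc(CSc3nc(C)cc(C)n3)cc(=O)c2c1` differs from compound 2 by methyl in place of hydrogen on an aromatic carbon. Among the measured compounds shown here, no measured step reports a methyl entering, and the one step touching this core, a step that the two limits leave unreadable from compound 1 to compound 2, is itself unreadable, so no direction can be read from the data. The expectation for compound 4 in this assay is that it also stays at the limit, with a step that the limit leaves unreadable from compound 2 to compound 4 expected to be no step beyond the scatter. The estimate for compound 4 is 30000 nM, with a range from 12000 nM to 100000 nM.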

Compound 4, half-maximal inhibitory concentration: > 25000 nM
Compound 4: no number, only a limit; the forecaster's own chance of this, stated with the estimate: 85%; the middle value lies beyond the limit too.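

In this assay compound 4 gives > 25000 nM, a limit and not a number. Within the data shown here, the steps to compound 4 from compound 1 and from compound 2 therefore cannot be read, and no new step follows. The compounds shown leave open whether any change on the shared core brings a readable number in this assay: the limit of > 25000 nM in this assay, at which 4 of the 4 values shown sit.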